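The compounds below may be only part of what the source reports. "The series", "measured", "known", "first", "only" and "open" are said of these compounds alone.

Measured compounds:
compound 1, `CCCOC(=O)C1=C(C)NC(=O)NC1c1ccoc1`, 50%
compound 2, `CC1=C(C(=O)OCc2ccccc2)C(c2ccoc2)NC(=O)N1`, 41%
compound 3, `CCCOC(=O)C1=C(C)N(C)C(=O)NC1c1ccoc1`, 1%

In an assay on membranes from CHO cells for displacement of a labelled ligand from adenosine receptor A1 (Homo sapiens), read by scintillation counting, with a stated time of 60 min, tested at 1 uM (on this read-out lower numbers stand for less inhibition and higher numbers for more inhibition at the one concentration tested (going by the name of the read-out)), compound 1 gives 50%, the highest of the three numbers. Compound 2, which carries phenyl in place of ethyl on a saturated chain carbon bound to an oxygen next to a carbonyl group, comes nearest with a number 9 percentage points lower from compound 1 to compound 2 (within the scatter). Compound 3, with methyl in place of hydrogen on an amide-type nitrogen in a ring, stands furthest away with a number 49 percentage points lower from compound 1 to compound 3 (beyond the scatter).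

Compound 4 has the structure `CC1=C(C(N)=O)C(c2ccoc2)NC(=O)N1` and has not yet been measured. It differs from compound 1 by amino in place of propoxy on a carbonyl carbon; the same difference, cut one bond further out, reads propoxycarbonyl to carbamoyl. Within the data shown here, of the two measured steps, only the one from compound 1 to compound 2 touches the group on this carbonyl carbon, and it stayed within the scatter; yet it kept the oxygen and altered only the chain, whereas here the propoxy as a whole leaves. The step from compound 1 to compound 3 sits at a different place and does not bear on it. Among the measured compounds shown here, no measured step therefore shows what removing the propoxy does, and the expectation is correspondingly uncertain. In this assay compound 4 is expected to give a number near 35%, within a range from 10% to 60%. This estimate means a number 15 percentage points lower from compound 1 to compound 4 (beyond the scatter), a step expected to be modest and downward, though its direction is not secured by the data shown.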

Compound 4, a percentage reported as inhibition, at one concentration (the size of the read-out at that concentration, not a potency): 1%
Compound 4: middle estimate off by 34 percentage points, on the high side; measured number outside the range, below it.
By their numbers in this assay, from the lowest: compounds 3 and 4 (each within the scatter of the next); then compounds 2 and 1 (each within the scatter of the next).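

In this assay, the group on this carbonyl carbon clearly matters: amino in place of propoxy gives a number 49 percentage points lower from compound 1 to compound 4 (beyond the scatter). The earlier step at this site, a number 9 percentage points lower from compound 1 to compound 2 (within the scatter), kept the oxygen and changed only the chain, so it showed that one chain can stand in for another, while the new step shows that the whole propoxy cannot be replaced by amino without losing most of the read-out. Nothing available here explains this drop.

The compounds shown do not separate the contribution of the chain from that of the oxygen, since the step to amino removes both together; an amide with a propyl chain on its nitrogen would keep the chain without the oxygen, and a methoxy group would keep the oxygen with a much shorter chain. Also open, as far as these compounds go, is how a carboxylic acid on this carbonyl carbon, or a butoxy group with its longer chain, would behave on the core of compound 1.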